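Nitro to trifluoromethyl on two related cores

This account rests on a few compounds, and the source may have more. Where it says the series, first, only, none or still open, it means among the compounds named here.

Compound 1 `CN1c2ccc(NC(=O)Nc3ccc([N+](=O)[O-])cc3)cc2C(C)(C)C(=O)C1(C)C` and compound 2 `CN1c2ccc(NC(=O)Nc3ccc(C(F)(F)F)cc3)cc2C(C)(C)C(=O)C1(C)C` share one core; compound 3 `CN1c2ccc(NC(=O)Nc3ccc([N+](=O)[O-])cc3)cc2C(C)(C)C(O)C1(C)C` and compound 4 `CN1c2ccc(NC(=O)Nc3ccc(C(F)(F)F)cc3)cc2C(C)(C)C(O)C1(C)C` share a second core. The difference between the two cores is not broken down here.

In a functional assay on A2780 cells (Homo sapiens) for inhibition, with a stated time of 72 h (on this read-out lower numbers stand for stronger inhibition and higher numbers for weaker inhibition), compound 1 gives 3800 nM. Compound 2 gives 2580 nM. The change between them is trifluoromethyl in place of nitro on an aromatic carbon and it made a step of a 1.5-fold lower number from compound 1 to compound 2 (0.17 log units; within the scatter), so the two values cannot be ordered against each other.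

On the second core, compound 3 gives 8400 nM, the highest of the three measured numbers, beyond the scatter from both compound 1 and compound 2. Compound 4 differs from compound 3 by trifluoromethyl in place of nitro on an aromatic carbon, the same change at the same place as between compound 1 and compound 2.

The step from compound 3 to compound 4 is expected to be a 1.5-fold lower number from compound 3 to compound 4 (0.18 log units; within the scatter), resting on the measured step of a 1.5-fold lower number from compound 1 to compound 2 (0.17 log units; within the scatter) on the first core. Compound 4 is therefore estimated at 5600 nM in this assay, with a likely range from 2500 nM to 12000 nM.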

Compound 4, half-maximal inhibitory concentration: 6700 nM
Estimate against measurement, compound 4: 1.2-fold (0.08 log units) below; low and high end bracket the measured number.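

In this assay, trifluoromethyl in place of nitro on the second core gives a 1.3-fold lower number from compound 3 to compound 4 (0.10 log units; within the scatter), so this pair cannot be ordered. Set beside the step on the first core, the change reads the same on both cores as far as these data can tell: the same change on two cores in this assay, a 1.5-fold lower number (0.17 log units; within the scatter) from compound 1 to compound 2 and a 1.3-fold lower number (0.10 log units; within the scatter) from compound 3 to compound 4, 1.2-fold (0.07 log units) apart, within the scatter of two such steps. This shows that, on these two cores, the swap leaves the number within the scatter each time, but it does not show that a step of real size carries from one core to another, and one matched pair per core says nothing about further cores in the series.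

Open, as far as these compounds go, is whether another group at the same place on the aromatic ring, such as an amine, a carboxylic acid or a nitrile, would give a step beyond the scatter. Also open, from the compounds shown here alone, is whether such a step would keep its size on both cores, which would be a sterner test of transfer than two steps this small.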